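Trifluoromethyl to methoxycarbonyl on the shared core

The source may report more compounds than this note shows. Statements on the series, on what has been measured and on what is new or still open speak of the compounds shown alone.

Measured compounds:
compound 1 `Cc1cc(CCC#N)cc(C)c1Oc1cc(Nc2ccc(C#N)cc2)c(N)cc1C(F)(F)F` — 120 mL.min-1.g-1
compound 2 `Cc1cc(/C=C/C#N)cc(C)c1Oc1cc(Nc2ccc(C#N)cc2)c(N)cc1C(F)(F)F` — 150 mL.min-1.g-1

Among the compounds with values here, in an in vitro ADME assay on microsomes from liver (Homo sapiens) for metabolic stability, tested at 1 uM (on this read-out lower numbers stand for slow clearance and higher numbers for fast clearance), compound 1 gives 120 mL.min-1.g-1, the lowest of the two numbers, with compound 2 at 150 mL.min-1.g-1 as its only neighbour; the step of a 1.3-fold higher number from compound 1 to compound 2 (0.10 log units; within the scatter) lies within the scatter, so the two are not distinguished on this read-out.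

Compound 3 `COC(=O)c1cc(N)c(Nc2ccc(C#N)cc2)cc1Oc1c(C)cc(CCC#N)cc1C` is not yet measured. It differs from compound 1 by methoxycarbonyl in place of trifluoromethyl on an aromatic carbon, while the 2-cyanoethyl chain, the amino group and the (4-cyanophenyl)amino group of compound 1 are kept.

Within the data shown here, no measured step touches this position or either of these groups. Among the measured compounds shown here, the only step in hand, a 1.3-fold higher number from compound 1 to compound 2 (0.10 log units; within the scatter), concerns the 2-cyanoethenyl in place of 2-cyanoethyl and was within the scatter, so it gives no bearing on the trifluoromethyl to methoxycarbonyl exchange. With nothing to anchor a direction, the expected step of a 1.1-fold higher number from compound 1 to compound 3 (0.03 log units; within the scatter) is none beyond the scatter, with a wide range on both sides. Compound 3 is therefore estimated at 130 mL.min-1.g-1 in this assay, between 60 mL.min-1.g-1 and 280 mL.min-1.g-1.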

Compound 3, intrinsic clearance in microsomes in the Homo sapiens assay: 40 mL.min-1.g-1
The estimate for compound 3 lay 3.3-fold (0.51 log units) above the measured number; measured number outside the range, below it.
By their numbers in the Homo sapiens assay, from the lowest: compound 3; then compounds 1 and 2 (each within the scatter of the next).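

Methoxycarbonyl in place of trifluoromethyl on this aromatic carbon is the first change in the series to move clearance beyond the scatter: in the Homo sapiens assay the exchange gives a 3.0-fold lower number from compound 1 to compound 3 (0.48 log units; beyond the scatter), while the change in the chain gave only a 1.3-fold higher number from compound 1 to compound 2 (0.10 log units; within the scatter). In a physicochemical assay for solubility, with a stated time of 4 h, at pH 2.0 (on this read-out higher numbers stand for higher solubility and lower numbers for lower solubility), compound 1 gives 0.33 ug/mL and compound 3 gives 21.8 ug/mL, so the position bears on a second read-out as well, with a larger step than in clearance. Within the data shown here, the one exchange thus pairs the lower clearance number with the higher solubility number, although this rests on a single pair and the solubility figures give no cause for the clearance step: the measured solubility of compound 1, 0.33 ug/mL, and of compound 3, 21.8 ug/mL, a 66-fold higher number (1.82 log units; beyond the scatter).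

On these data alone, whether the exchange gives a step of like size on the 2-cyanoethenyl chain of compound 2 stays open, and one pair cannot separate what the departure of trifluoromethyl and the arrival of methoxycarbonyl each contribute. Also open, as far as these compounds go, is how a carboxylic acid or a primary amide in the same place would stand on either read-out.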